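Sulfonamide series: a fluoro added to compound 1

The source may hold more compounds than are shown below. What is called first, only, known or untested is meant among the compounds shown, and "the series" means these compounds.

Compound 1 `O=S(=O)(Nc1ccc2oc(-c3ccccc3)nc2c1)c1cccc(C(F)(F)F)c1` is the reference point. In an assay on cells for inhibition of HSP60/HSP10 (Homo sapiens), with a stated time of 60 min (a higher number here means a weaker inhibitor, a lower number a stronger inhibitor), compound 1 gives only a limit, > 100000 nM. Compound 2 `O=S(=O)(Nc1ccc2oc(-c3ccccc3)nc2c1)c1cccc(F)c1` carries fluoro in place of trifluoromethyl. In this assay compound 2 likewise gives only a limit, > 100000 nM. The step that the two limits leave unreadable from compound 1 to compound 2 cannot be read, since both values sit at the limit of > 100000 nM in this assay, at which 2 of the 2 values shown sit. Compound 3 `O=S(=O)(Nc1ccc2oc(-c3ccccc3)nc2c1)c1ccc(F)c(C(F)(F)F)c1` differs from compound 1 by fluoro in place of hydrogen on an aromatic carbon. Among the measured compounds shown here, no measured step gives a readable size for such a change, so no movement beyond the scatter is expected in this assay. Compound 3 is expected to show 150000 nM, in the range 50000 nM to 500000 nM, most probably again reported only as a limit. The expected step that the limit leaves unreadable from compound 1 to compound 3 is nominal.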

Compound 3, half-maximal inhibitory concentration: 69000 nM
Estimate against measurement, compound 3: 2.2-fold (0.34 log units) above; low and high end bracket the measured number.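

In this assay compound 3, at 69000 nM, is the only compound shown that gives a number, so fluoro on this aromatic carbon, ortho to a trifluoromethyl group and para to a large group, yields the first readable step: an at least 1.4-fold lower number from compound 1 to compound 3 (0.16 log units; that floor lies within the scatter). With that floor inside the scatter, no real gain from the fluoro is established. The other values remain limits: the limit of > 100000 nM in this assay, at which 2 of the 3 values shown sit.

Open, from the compounds shown here alone, is whether an amine, a methoxy group or a carboxylic acid at this position would move the number further. Also open, going by these compounds, is whether fluoro here gives a number without the trifluoromethyl group.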